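The compounds below may be only part of what the source reports. "The series", "measured", "known", "first", "only" and "open" are said of these compounds alone.

Measured so far:
Compound 1, `O=c1c(C2N=C(c3ccccc3)SS2)coc2ccccc12`: 48%
Compound 2, `O=c1c(C(=S)Nc2ccccc2)coc2cc(Cl)c(Cl)cc12`: 4%

Both compounds were tested in a functional assay on HEp-2 cells (Homo sapiens) for inhibition, read by sulforhodamine B assay, with a stated time of 48 h, tested at 100 uM; a lower number here means less inhibition of growth, a higher number more inhibition of growth at the concentration tested. In this assay, among the compounds with values here, compound 1 gives 48%, the higher of the two numbers known here. Compound 2 differs from compound 1 in several places, not in one alone. In this assay, within the data shown here, compound 2 gives 4%, a number well beyond the scatter below that of compound 1; as no single step connects the two, nothing more than these two numbers can be read from the pair.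

The next compound, compound 3, `O=c1c(C2N=C(c3ccccc3)SS2)coc2ccc(Cl)cc12`, has not yet been measured in this assay. It differs from compound 1 in one place only: chloro in place of hydrogen on an aromatic carbon. Among the measured compounds shown here, no step between two measured compounds tells how such a change plays out in this assay, so the expectation rests on compound 1 alone. A small step, in either direction or none beyond the scatter, is what is expected from compound 1 to compound 3, about a number 2 percentage points higher from compound 1 to compound 3 (within the scatter). The value estimated for compound 3 in this assay is therefore 50%, expected to fall between 30% and 70%.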

Compound 3, percent growth inhibition at one concentration: 69%
Compound 3: middle estimate off by 19 percentage points, on the low side; measured number inside the range.
By their numbers in this assay, from the lowest: compound 2; then compound 1; then compound 3.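

In this assay, within the data shown here, chloro in place of hydrogen on an aromatic carbon of the core of compound 1 gives a number 21 percentage points higher from compound 1 to compound 3 (beyond the scatter) and is the first single change that can be read. It shows that this carbon, meta to a fused ring and para to a fused ring, is not a silent spot on the core: one chlorine atom in place of hydrogen is enough to move the growth inhibition seen at the tested concentration by more than the usual scatter of such measurements. Nothing measured here accounts for this rise.

The compounds shown leave open whether the rise belongs to chloro itself or would also come with another group at this carbon, such as fluoro, methyl, methoxy or an amine. Among these compounds, they also leave open whether chloro on another carbon of this ring would do the same, and whether the step would hold at other concentrations, since a single pair at one concentration gives only this one comparison.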